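The source may hold more compounds than are shown below. What is called first, only, known or untested is meant among the compounds shown, and "the series" means these compounds.

Measured compounds in hand:

- compound 1, `Cn1nc(-c2ccccc2)c2cc(C(=N)Nc3ccccc3)ncc21`: 17300 nM
- compound 2, `CN1CCN(c2ccc(NC(=N)c3cc4cnn(C)c4cn3)cc2)CC1`: 32300 nM
- compound 3, `COc1ccc(Cn2nc(-c3ccccc3)c3cc(C(=N)Nc4ccccc4)ncc32)cc1`: 6300 nM

All three were run in a functional assay on PC-3 cells (Homo sapiens) for cytotoxicity, read by MTT assay, with a stated time of 72 h; a higher number here means a weaker inhibitor, a lower number a stronger inhibitor. Compound 2 gives the highest of the three numbers, with 32300 nM; against compound 1 its value sits within the scatter, against compound 3 it is beyond it. The difference between the core of compound 1 and the core of compound 2 is not broken down here.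

Among the measured compounds shown here, the one change that is counted twice in this set is 4-methoxyphenyl in place of hydrogen on a saturated chain carbon bound to an aromatic nitrogen. Within the core of compound 1 it produced a 2.7-fold lower number from compound 1 to compound 3 (0.44 log units; beyond the scatter), a step beyond the scatter.

Compound 4, `COc1ccc(Cn2ncc3cc(C(=N)Nc4ccc(N5CCN(C)CC5)cc4)ncc32)cc1`, is not yet measured in this assay. It stands to compound 2 exactly as compound 3 stands to compound 1: the difference is 4-methoxyphenyl in place of hydrogen on a saturated chain carbon bound to an aromatic nitrogen, and the place line is identical word for word, so this is the same change on a different core.

The expectation rests on a single precedent. Because the same change gave a 2.7-fold lower number from compound 1 to compound 3 (0.44 log units; beyond the scatter) on the core of compound 1, a step of similar size is expected on the core of compound 2, that is a 2.7-fold lower number from compound 2 to compound 4 (0.43 log units; beyond the scatter). For the measured compounds named here, with only one prior instance, and a core that differs in more than one place, the expected range is kept wide. Compound 4 is thus estimated at 12000 nM in this assay, with a range from 5000 nM to 30000 nM.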

Compound 4, half-maximal inhibitory concentration: 6100 nM
Beside the measured number, compound 4's estimate is 2.0-fold (0.29 log units) above it; the measured number falls inside the stated range.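

In this assay, 4-methoxyphenyl in place of hydrogen on a saturated chain carbon bound to an aromatic nitrogen gives a 5.3-fold lower number from compound 2 to compound 4 (0.72 log units; beyond the scatter), so the change lowers the number on this second core as well. The two steps run in the same direction and their sizes cannot be told apart: the same change on two cores in this assay, a 2.7-fold lower number (0.44 log units; beyond the scatter) from compound 1 to compound 3 and a 5.3-fold lower number (0.72 log units; beyond the scatter) from compound 2 to compound 4, 1.9-fold (0.29 log units) apart, within the scatter of two such steps. This supports carrying the change between these two cores as a step of comparable size, but it rests on just two pairs, does not establish a fixed step size across the series, and does not show what in the change produces the lower number.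

Open, going by these compounds, is how the step would read with plain benzyl, 4-chlorobenzyl or a longer chain such as propyl in place of 4-methoxybenzyl, which would help separate the contribution of the methoxy group from that of the aromatic ring and its chain carbon. Also open, on these data alone, is whether the same step would appear on a further core, for instance one bearing a carboxylic acid or a primary amine.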